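From (Chloromethyl)carbonyl to 4-(Trifluoromethyl)benzyl on the Ring Nitrogen

The source may report more compounds than this note shows. Statements on the series, on what has been measured and on what is new or still open speak of the compounds shown alone.

Compound 1, `CCN(CC)c1ccc2cc(C(=O)c3ccc(N4CCN(C(=O)CN5CCN(C(=O)CCl)CC5)CC4)cc3)oc2c1`, carries a (chloromethyl)carbonyl group on an amine nitrogen in a ring. In a functional assay on HCT-116 cells (Homo sapiens) for cytotoxicity, read by MTT assay, with a stated time of 48 h (a higher number here means a weaker inhibitor, a lower number a stronger inhibitor), compound 1 gives only a limit, > 40000 nM, so its true strength is not pinned down. Compound 1 thus rests at the limit of > 40000 nM in this assay, at which 1 of the 2 values shown sits. Its close relative compound 2, `CCN(CC)c1ccc2cc(C(=O)c3ccc(N4CCN(C(=O)CN5CCN(C(=O)/C=C/c6ccccc6)CC5)CC4)cc3)oc2c1`, differs only in having 2-phenylethenyl in place of chloromethyl on the carbonyl carbon; in this assay compound 2 gives 6810 nM. That single change produced an at least 5.8-fold lower number from compound 1 to compound 2 (0.76 log units; beyond the scatter), a gain beyond the usual scatter.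

The step followed here leads from compound 1 to compound 3, `CCN(CC)c1ccc2cc(C(=O)c3ccc(N4CCN(C(=O)CN5CCN(Cc6ccc(C(F)(F)F)cc6)CC5)CC4)cc3)oc2c1`. The change is 4-(trifluoromethyl)benzyl in place of (chloromethyl)carbonyl on an amine nitrogen in a ring. As in the step to compound 2, the chlorine-bearing group leaves and a six-membered aromatic ring of carbon only enters, though here the carbonyl also disappears. Among the compounds with values here, the step to compound 2 is the only measured guide, and it points toward a lower number of comparable size. For compound 3 the expected step is an at least 4.4-fold lower number from compound 1 to compound 3 (0.64 log units; beyond the scatter). Compound 3 is therefore estimated at 9000 nM, with a likely range from 2500 nM to 40000 nM.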

Compound 3, half-maximal inhibitory concentration: > 40000 nM
Compound 3: no number, only a limit; the forecaster's own chance of this, stated with the estimate: 25%; middle value at least 4.4-fold (0.64 log units) away from the limit.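

Compound 3, like compound 1, gives only a limit rather than a number in this assay: the limit of > 40000 nM in this assay, at which 2 of the 3 values shown sit.

The step between two limits cannot be read, so the useful comparison on this ring nitrogen is the one in which 4-(trifluoromethyl)benzyl stands in place of (2-phenylethenyl)carbonyl, and it gives an at least 5.8-fold higher number from compound 2 to compound 3 (0.76 log units; beyond the scatter). The earlier step suggested that a six-membered aromatic ring of carbon only could bring a measurable value at this place, but compound 3 shows that such a ring does not do so in every setting: among the three compounds, only compound 2, which has both a carbonyl on the ring nitrogen and an aromatic ring further out, gives a number.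

The compounds shown do not separate the loss of the carbonyl from the change in the attached chain or from the presence of the trifluoromethyl group. A plain benzyl group, or a (2-phenylethenyl)carbonyl group carrying trifluoromethyl on its aromatic ring, would help to tell these apart on the same shared core.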